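A few compounds are considered here, and "the series" means these few. Any claim that something is new, unique, unknown or untested is made for them only; others in the source may bear on it.

The measured compounds:

compound 1, `O=C1/C(=C/c2ccc(Cl)cc2)Cc2ccccc21`, 54100 nM
compound 2, `O=C1/C(=C/c2ccc(Br)cc2)Cc2ccccc21`, 64800 nM
compound 3, `O=C1CCCCC/C1=C\c1cccc(Cl)c1`, 144000 nM

All three were tested in a functional assay on L1210 cells (Mus musculus) for inhibition; a higher number here means a weaker inhibitor, a lower number a stronger inhibitor. Compound 1 and compound 2 share one core and differ in a single place: bromo in place of chloro on an aromatic carbon. That change gave a 1.2-fold higher number from compound 1 to compound 2 (0.08 log units; within the scatter), so the two values cannot be told apart. Compound 3 has another core, and the difference between the two cores is not broken down here. Compound 3 gives 144000 nM, the highest of the three numbers; compound 2 gives 64800 nM, and compound 1 gives 54100 nM, both beyond the scatter from compound 3.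

Compound 4, `O=C1CCCCC/C1=C\c1cccc(Br)c1`, has not yet been measured. It differs from compound 3 in one place: bromo in place of chloro on an aromatic carbon. Among the measured compounds shown here, this is the same kind of change as the one from compound 1 to compound 2, but the surroundings differ: in compound 3 the aromatic carbon is meta to a group of 9 heavy atoms, whereas in compound 1 it is para to a large group. Because the earlier swap gave only a 1.2-fold higher number from compound 1 to compound 2 (0.08 log units; within the scatter), a step of similar size is expected here, that is, roughly a 1.2-fold higher number from compound 3 to compound 4 (0.07 log units; within the scatter) expected from compound 3 to compound 4. In this assay compound 4 is therefore estimated at 170000 nM. The expected range for compound 4 runs from 80000 nM to 360000 nM.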

Compound 4, half-maximal inhibitory concentration: 246000 nM
The estimate for compound 4 lay 1.4-fold (0.16 log units) below the measured number, and the stated range covers the measured number.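

In this assay, putting bromo in place of chloro on the core of compound 3 gave a 1.7-fold higher number from compound 3 to compound 4 (0.23 log units; within the scatter) and so cannot be told apart from the ordinary spread of repeated measurements. Set beside the same swap on the core of compound 1, the new step agrees with the earlier one, and neither step can be told from no change at all: the same change on two cores in this assay, a 1.2-fold higher number (0.08 log units; within the scatter) from compound 1 to compound 2 and a 1.7-fold higher number (0.23 log units; within the scatter) from compound 3 to compound 4, 1.4-fold (0.15 log units) apart, within the scatter of two such steps. Among the compounds shown here, this shows that, on the two cores at hand, exchanging one of these halogens for the other left the number where it was within the scatter, but with only two pairs it does not show that the same would hold on a further core, and it gives no reason why the swap matters so little.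

The compounds shown carry only chloro or bromo on the aromatic ring, so it stays open how a fluoro, a methoxy, an amine or a carboxylic acid on that carbon would read in this assay. As far as these compounds go, it also stays open whether any such group would shift the number by more than the scatter, which neither halogen swap did.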